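Swapping pyridin-4-yl for pyrimidin-5-yl: an expectation

A few compounds are considered here, and "the series" means these few. Any claim that something is new, unique, unknown or untested is made for them only; others in the source may bear on it.

Compound 1 `COc1ccc(S(=O)(=O)/C=C/c2ccccn2)cc1`: in an assay on U2OS cells for activation of nuclear factor erythroid 2-related factor 2 (Homo sapiens), read by chemiluminescence, with a stated time of 6 h (on this read-out lower numbers stand for an effect already at smaller amounts and higher numbers for an effect only at larger amounts of compound), compound 1 gives > 10000 nM, which is a limit, not a number.
Compound 2 `COc1ccc(S(=O)(=O)/C=C/c2cccnc2)cc1`: in this assay compound 2 gives > 10000 nM, again a limit rather than a number.
Compound 3 `COc1ccc(S(=O)(=O)/C=C/c2ccncc2)cc1`: in this assay compound 3 gives 1200 nM.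

Compound 3 therefore stands as the only one of the three with a number; the other two sit at the limit of > 10000 nM in this assay, at which 2 of the 3 values shown sit. The moves that reach it are both sizeable: an at least 8.3-fold lower number from compound 1 to compound 3 (0.92 log units; beyond the scatter) and an at least 8.3-fold lower number from compound 2 to compound 3 (0.92 log units; beyond the scatter). The move between the two weak compounds, a step that the two limits leave unreadable from compound 1 to compound 2, cannot be sized. Compound 4 `COc1ccc(S(=O)(=O)/C=C/c2cncnc2)cc1` has not yet been measured. It differs from compound 3 in one place: pyrimidin-5-yl in place of pyridin-4-yl on a double-bonded chain carbon bound to a double-bonded chain carbon. Among the compounds with values here, none of the measured steps tests a ring with two hetero atoms; they only show that, among the three pyridines, pyridin-4-yl is the arrangement that yields a readable number. Whether the second ring nitrogen changes the number cannot be read from these compounds. A moderate rise in the number is nonetheless the expected outcome, estimated as a 2.5-fold higher number from compound 3 to compound 4 (0.40 log units; beyond the scatter), and a limit remains possible. Compound 4 is estimated at 3000 nM, with a range from 800 nM to 12000 nM.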

Compound 4, half-maximal effective concentration: > 10000 nM
Compound 4: a limit, no number; the forecaster's own chance of this, stated with the estimate: 30%; middle value at least 3.3-fold (0.52 log units) away from the limit.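

Within this small set, the readable number does not survive the change from pyridin-4-yl to pyrimidin-5-yl: in this assay, the change gives an at least 8.3-fold higher number from compound 3 to compound 4 (0.92 log units; beyond the scatter). Within the data shown here, this is the first test here of a ring with 2 hetero atoms on the double-bonded chain carbon, and it leaves compound 3 as the only compound with a number, so having a ring nitrogen where pyrimidin-5-yl carries one does not by itself preserve a readable value once the ring holds a second nitrogen. The value of compound 4 is a limit, not a number, and it is the same limit shown by compounds 1 and 2: the limit of > 10000 nM in this assay, at which 3 of the 4 values shown sit.

The steps linking compound 4 to compounds 1 and 2 cannot be read, so no order can be given among these three compounds, and how far each lies beyond the limit stays unknown. The compounds shown also cannot tell why the number is lost, or whether a plain phenyl ring at this place, or an amine or a methyl group added to the pyridin-4-yl ring, would give a number at all.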